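A few compounds are considered here, and "the series" means these few. Any claim that something is new, unique, unknown or untested is made for them only; others in the source may bear on it.

Working notes on the series.

Compound 1 `C[C@H](c1ccccc1)N1C(=O)O[C@](Cc2ccccc2)(c2nc(-c3ccccc3)co2)C1=O` is the reference point. In an ADME assay (liver) for metabolic stability, with Liver microsome (Rattus norvegicus) as the target, using microsomes, with a stated time of 0.5 h, tested at 1 uM (a lower number here means that less of the compound is left, a higher number that more of the compound is left), compound 1 gives 15%, the highest of the three numbers in hand. Compound 2 `C[C@H](c1ccccc1)N1C(=O)O[C@](Cc2ccccc2)(c2ncc(Cc3ccccc3)[nH]2)C1=O` gives 0% in this assay, and compound 3 `COc1cc(OC)cc(-c2cnc([C@@]3(Cc4ccccc4)OC(=O)N([C@H](C)c4ccccc4)C3=O)[nH]2)c1` gives 4%, so compound 1 sits beyond the scatter above both, with compound 3 the nearer and compound 2 the further of the two.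

Among the measured compounds shown here, the only one-place step measured, a number 4 percentage points higher from compound 2 to compound 3 (within the scatter), concerns a substituent on an aromatic carbon of the azole and does not touch the azole itself; it lies within the scatter and gives no direct reading for the change considered next.

Compound 4 `C[C@H](c1ccccc1)N1C(=O)O[C@](Cc2ccccc2)(c2nnc(-c3ccccc3)[nH]2)C1=O` differs from compound 1 by 5-phenyl-4H-1,2,4-triazol-3-yl in place of 4-phenyl-1,3-oxazol-2-yl on a saturated ring carbon. For the measured compounds named here, no measured step alters the azole at the saturated ring carbon, so the expectation rests only on the spread of the three values: compound 1 with its oxazole stands highest, while compound 2 and compound 3, each carrying an azole with one hydrogen-bond donor, stand lower.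

On that basis compound 4, whose triazole also carries one hydrogen-bond donor, is expected to come in lower than compound 1, with an estimated step of a number 9 percentage points lower from compound 1 to compound 4 (within the scatter) in this assay. The estimate for compound 4 is 6%, with a range from 0% to 18%.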

Compound 4, percent of the compound remaining: 29%
For compound 4 the middle estimate is 23 percentage points below the measured one, and the stated range ends below it.
By their numbers in this assay, from the lowest: compounds 2 and 3 (each within the scatter of the next); then compound 1; then compound 4.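

In this assay, among the compounds shown here, the change of azole on the saturated ring carbon gives a number 14 percentage points higher from compound 1 to compound 4 (beyond the scatter), the first reading for this position and the first step that lies beyond the scatter. The two groups match in heavy-atom count and in hydrogen-bond acceptors and both keep the phenyl ring, yet the entering 5-phenyl-4H-1,2,4-triazol-3-yl has a hydrogen-bond donor that the leaving 4-phenyl-1,3-oxazol-2-yl lacks, so in this pair the gain of a donor comes with more of the compound left, not less. Nothing available accounts for this rise.

As far as these compounds go, the reading rests on a single pair, so it remains open whether the higher number would hold on the triazole with a group other than phenyl on its aromatic carbon, such as a 3,5-dimethoxyphenyl or benzyl group, or with a carboxylic acid on the phenyl ring. Also open, from the compounds shown here alone, is what a methyl group on the triazole nitrogen, in place of its hydrogen, would do to the number, which would test the donor directly.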